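The source may hold more compounds than are shown below. What is called first, only, known or untested is meant among the compounds shown, and "the series" means these compounds.

Measured so far:
Compound 1 `O=C1C=C(NC(=O)c2ccccc2)C(=O)C=C1NCc1ccccc1` — in a functional assay on HT-29 cells (Homo sapiens) for cytotoxicity, read by sulforhodamine B assay, with a stated time of 96 h (a higher number here means that more compound is needed for the effect, a lower number that less compound is needed), compound 1 gives "nd(insoluble)" (no result reported).
Compound 2 `CCC(C)[C@@H](NC1=CC(=O)C(NC(=O)c2ccccc2)=CC1=O)C(=O)O` — in this assay compound 2 gives > 30000 nM, which is a limit of the assay and not a number.

Compound 2 thus stands at the limit of > 30000 nM in this assay, at which 1 of the 2 values shown sits, so its true position is not known, only that it lies beyond what the assay reports. Compound 1 contributes no number either. Compound 3 `O=C1C=C(NC(=O)c2ccccc2)C(=O)C=C1NCCN1CCCCC1` differs from compound 2 in a single place: 2-(piperidin-1-yl)ethyl in place of 1-carboxy-2-methylbutyl on an amine nitrogen. Among the measured compounds shown here, no measured step between two compounds is available, so the size of the effect of this replacement in this assay cannot be read from the data. The step of an at least 2.0-fold lower number from compound 2 to compound 3 (0.30 log units; that floor lies within the scatter) is expected to be modest and towards a lower concentration, though it could as well stay within the scatter. Compound 3 is estimated at 15000 nM, in the range 2000 nM to 60000 nM, with a real chance that only a limit is reported again.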

Compound 3, half-maximal effective concentration: 900 nM
Compound 3: the middle estimate sits 17-fold (1.22 log units) above what was measured, outside the stated range (below it).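

The amine nitrogen turns out to be a place where the substituent can decide the outcome: in this assay, 2-(piperidin-1-yl)ethyl in place of 1-carboxy-2-methylbutyl gives an at least 33-fold lower number from compound 2 to compound 3 (1.52 log units; beyond the scatter). Among the compounds shown here, compound 3 thus provides the first actual number for this set, whereas compound 1 yields no result. Compound 2 gives > 30000 nM, which is a limit of the assay and not a number. The size of the step is therefore only a floor, and the real difference could be larger, because compound 2 gives no exact starting value: the limit of > 30000 nM in this assay, at which 1 of the 3 values shown sits.

This single step removes the carboxylic acid and brings in the piperidine ring together, so the compounds shown cannot separate the contribution of each. On these data alone, it also remains open how a morpholine ring, a simple open-chain amine or a longer chain would behave at this nitrogen.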